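The compounds below may be only part of what the source reports. "The series", "measured", "known", "first", "only" and "open" are said of these compounds alone.

Measured so far in a functional assay on BGC-823 cells (Homo sapiens) for cytotoxicity, read by CCK-8 assay, with a stated time of 24 h; on this read-out lower numbers stand for stronger inhibition and higher numbers for weaker inhibition:

Compound 1 `C/C(=C\c1cc(-c2ccccc2)cs1)C(N)=O` gives a value that is only a limit of the assay, > 50000 nM.
Compound 2 `C/C(=C\c1nc(-c2ccccc2)cs1)C(N)=O` likewise gives only a limit, > 50000 nM.
Compound 3 `C/C(=C\c1nc(-c2ccc(C)cc2)cs1)C(N)=O` also gives only a limit, > 50000 nM.

Compound 3 comes from compound 2 by methyl in place of hydrogen on an aromatic carbon, and the step that the two limits leave unreadable from compound 2 to compound 3 cannot be read because of the limit of > 50000 nM in this assay, at which 3 of the 3 values shown sit. The cores of compound 1 and compound 2 differ, but that difference is not broken down here.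

Compound 4 `C/C(=C\c1cc(-c2ccccc2C)cs1)C(N)=O` is not yet measured in this assay. It comes from compound 1 by methyl in place of hydrogen on an aromatic carbon, the same kind of change as from compound 2 to compound 3, though there the methyl sits para to a large group and here ortho to a large group. Since compound 1 gives > 50000 nM, compound 4 is expected to sit at 60000 nM, a step that the limit leaves unreadable from compound 1 to compound 4, most likely again reported only as a limit.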

Compound 4, half-maximal inhibitory concentration: > 50000 nM
Compound 4 was reported as a limit (the forecaster's own chance of this, stated with the estimate: 80%); the middle value is on the limit's open side.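

No new step can be read between compound 1 and compound 4, because both values are only limits: the limit of > 50000 nM in this assay, at which 4 of the 4 values shown sit.

The compounds shown leave open whether the methyl ortho to a large group in compound 4 changes cytotoxicity at all.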